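Nitrobenzylidene cyclohexanones: a phenol in place of methoxy

This account rests on a few compounds, and the source may have more. Where it says the series, first, only, none or still open, it means among the compounds named here.

Measured so far:
compound 1 `COc1ccc(/C=C2\CCC/C(=C\c3ccc([N+](=O)[O-])cc3)C2=O)cc1` — > 400000 nM
compound 2 `O=C1/C(=C/c2ccc(O)cc2)Cc2ccccc2/C1=C\c1ccc([N+](=O)[O-])cc1` — 5200 nM

In a functional assay on HSC-2 cells (Homo sapiens) for cytotoxicity (on this read-out lower numbers stand for higher toxicity in this test and higher numbers for lower toxicity in this test), compound 1 gives only a limit, > 400000 nM, rather than a number. That limit is the point at which one of the two values shown sits (the limit of > 400000 nM in this assay, at which 1 of the 2 values shown sits). Within the data shown here, compound 2, built on a different core, gives 5200 nM in this assay; no step is counted between compound 2 and compound 1, so their two values simply stand as they are.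

Compound 3 `COc1cc(/C=C2\CCC/C(=C\c3ccc([N+](=O)[O-])cc3)C2=O)ccc1O` differs from compound 1 in one place: 4-hydroxy-3-methoxyphenyl in place of 4-methoxyphenyl on a double-bonded chain carbon bound to a double-bonded ring carbon.

With compound 1 known only as a limit, the size of the step cannot be anchored on a measured value. The estimate for compound 3 in this assay is 150000 nM, expected to fall between 20000 nM and 400000 nM, which would mean an expected step of an at least 2.6-fold lower number from compound 1 to compound 3 (0.42 log units; beyond the scatter) toward higher toxicity, with a real chance that the assay again reports only a limit.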

Compound 3, half-maximal cytotoxic concentration: 2800 nM
For compound 3 the middle estimate is 54-fold (1.73 log units) above the measured one, outside the stated range (below it).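

In this assay, 4-hydroxy-3-methoxyphenyl in place of 4-methoxyphenyl on a double-bonded chain carbon bound to a double-bonded ring carbon gives an at least 140-fold lower number from compound 1 to compound 3 (2.15 log units; beyond the scatter), toward higher toxicity in this test. Among these compounds, this is the first step measured at this place, and it shows that a change confined to this aryl group, with the rest of the core of compound 1 kept, can be enough to bring a measurable value into this assay. The value for compound 1 is a limit and not a number, so the step has only a lower bound: the limit of > 400000 nM in this assay, at which 1 of the 3 values shown sits.

The entering group carries both a hydroxy and a methoxy in new places, and the compounds shown do not separate what each contributes to the step. On these data alone, whether an amine or a carboxylic acid in place of the hydroxy would give a similar value also remains open.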